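Aryl ether, amine and thioether variants on a shared diamine core

The source may hold more compounds than are shown below. What is called first, only, known or untested is meant among the compounds shown, and "the series" means these compounds.

Measured so far:
- compound 1 `Nc1cc(N)c2nc(-c3ccccc3)c(Oc3ccc(Cl)c(Cl)c3)nc2c1`: 30900 nM
- compound 2 `Nc1cc(N)c2nc(-c3ccccc3)c(NCc3ccc(Cl)c(Cl)c3)nc2c1`: 37200 nM
- compound 3 `CCOC(=O)[C@H](CCC(=O)O)NC(=O)c1ccc(Sc2nc3cc(N)cc(N)c3nc2-c2ccccc2)cc1`: a limit, < 100000 nM

In a functional assay on SF-295 cells (Homo sapiens) for inhibition, read by sulforhodamine B assay, with a stated time of 48 h (on this read-out higher numbers stand for weaker inhibition of growth and lower numbers for stronger inhibition of growth), compound 1 gives 30900 nM. Compound 2 gives 37200 nM in this assay, and the gap between compound 1 and compound 2 is within the scatter, so no order between them is claimed. For compound 3 this assay reports only a limit, < 100000 nM; this is noted as the limit of < 100000 nM in this assay, at which 1 of the 3 values shown sits.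

Compound 4 `Nc1cc(N)c2nc(-c3ccccc3)c(Sc3ccc(F)cc3)nc2c1` has not yet been measured in this assay. It differs from compound 1 by (4-fluorophenyl)sulfanyl in place of 3,4-dichlorophenoxy on an aromatic carbon. Among the compounds with values here, no step between measured compounds bears on this change, so no direction beyond the scatter is expected; the step from compound 1 to compound 4 is estimated as a 1.1-fold higher number from compound 1 to compound 4 (0.05 log units; within the scatter). Compound 4 is expected to give 35000 nM in this assay, within 12000 nM to 100000 nM.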

Compound 4, concentration for total growth inhibition: 30200 nM
Compound 4: middle estimate off by 1.2-fold (0.06 log units), on the high side; measured number inside the range.
By their numbers in this assay, from the lowest: compounds 4, 1 and 2 (each within the scatter of the next).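

In this assay, swapping 3,4-dichlorophenoxy for (4-fluorophenyl)sulfanyl on the aromatic carbon next to the ring nitrogen gives a 1.0-fold lower number from compound 1 to compound 4 (0.01 log units; within the scatter). This position therefore tolerates a sulfur link with a singly fluorinated ring as well as an oxygen link with a dichlorinated ring, with no difference that can be read. The change alters the linking atom and the ring halogens together, and nothing at hand gives a cause for the result.

Going by these compounds, the separate contributions of the link and the halogens remain open. So does the outcome with a morpholine or a simple alkyl chain at this position.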